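This account rests on a few compounds, and the source may have more. Where it says the series, first, only, none or still open, it means among the compounds named here.

Measured in a functional assay on HL60/MX2 cells (Homo sapiens) for antiproliferative activity, read by MTT assay, with a stated time of 48 h; on this read-out higher numbers stand for weaker inhibition and lower numbers for stronger inhibition:
- compound 1 `Cn1c(N)c(-c2nc3ccccc3[nH]2)c2nc(C#N)c(C#N)nc21` gives > 50000 nM
- compound 2 `CCn1c(N)c(-c2nc3ccccc3[nH]2)c2nc(C#N)c(C#N)nc21` gives > 50000 nM
- compound 3 `CCN(CC)CCn1c(N)c(-c2nc3ccccc3[nH]2)c2nc(C#N)c(C#N)nc21` gives 7150 nM

Compound 1 gives only a limit, > 50000 nM, and not a number. Compound 2 likewise gives only a limit, > 50000 nM. Compound 3 gives a true number, 7150 nM.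

Compound 4 `N#Cc1nc2c(-c3nc4ccccc4[nH]3)c(N)n(CCN3CCCC3)c2nc1C#N` departs from compound 1 by one change: (pyrrolidin-1-yl)methyl in place of hydrogen on a saturated chain carbon bound to an aromatic nitrogen. The closest measured change is an at least 6.9-fold lower number from compound 1 to compound 3 (0.84 log units; beyond the scatter), where (diethylamino)methyl enters at the same place. The step of an at least 6.9-fold lower number from compound 2 to compound 3 (0.84 log units; beyond the scatter) points the same way, while a step that the two limits leave unreadable from compound 1 to compound 2 cannot be read. In this assay, a step of similar size towards lower numbers is therefore expected. The expected step runs an at least 7.1-fold lower number from compound 1 to compound 4 (0.85 log units; beyond the scatter). For compound 4 the estimate is 7000 nM, with an estimated range of 2500 nM to 20000 nM.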

Compound 4, half-maximal inhibitory concentration: > 50000 nM
Compound 4: no number, only a limit; the forecaster's own chance of this, stated with the estimate: 12%; at least 7.1-fold (0.85 log units) between middle value and limit.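

In this assay compound 4 gives only a limit, > 50000 nM, and not a number. Pyrrolidin-1-yl in place of diethylamino at the end of the chain gives an at least 6.9-fold higher number from compound 3 to compound 4 (0.84 log units; beyond the scatter), so an amine at this place does not by itself yield a readable value, and compound 3 alone among the compounds shown does. The steps to compound 4 from compound 1 and compound 2 cannot be read because both ends are limits: the limit of > 50000 nM in this assay, at which 3 of the 4 values shown sit.

On these data alone, whether other amines at this chain end, such as dimethylamino, piperidine or morpholine, give a readable value stays open. So does the effect of a longer chain carrying the diethylamino group.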